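Swapping a fluorinated phenyl for a saturated seven-membered ring

The source may report more compounds than this note shows. Statements on the series, on what has been measured and on what is new or still open speak of the compounds shown alone.

Compound 1 `O=C1Nc2c(ccc(F)c2F)C1(c1ccc(O)cc1)c1ccc(F)cc1` was tested in a functional assay on PC-3 cells (Homo sapiens) for cytotoxicity, read by WST assay, with a stated time of 72 h (a higher number here means a weaker inhibitor, a lower number a stronger inhibitor), where compound 1 gives 8.6 nM, the lowest of the two numbers measured. Within the data shown here, compound 2 `O=C1Nc2c(ccc(F)c2F)C1(c1ccc(O)cc1)c1ccc(F)c(F)c1` carries one more fluorine on an aromatic carbon, and in this assay compound 2 gives 19 nM; the step of a 2.2-fold higher number from compound 1 to compound 2 (0.34 log units; beyond the scatter) is the only measured change so far.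

Compound 3 `O=C1Nc2c(ccc(F)c2F)C1(c1ccc(O)cc1)C1CCCCCC1` has not yet been measured. It differs from compound 1 in one place: cycloheptyl in place of 4-fluorophenyl on a saturated ring carbon. Among the measured compounds shown here, no measured step involves an exchange of this kind, and the one step available, a fluorine for a hydrogen on an aromatic ring, is far smaller than trading an aromatic ring for a saturated one. The expectation is therefore uncertain and leans toward a weaker inhibitor, with a broad range. Compound 3 is estimated to give 40 nM in this assay, between 6 nM and 250 nM, which means an expected step of a 4.7-fold higher number from compound 1 to compound 3 (0.67 log units; beyond the scatter).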

Compound 3, half-maximal inhibitory concentration: 12 nM
The estimate for compound 3 lay 3.3-fold (0.52 log units) above the measured number; low and high end bracket the measured number.
By their numbers in this assay, from the lowest: compounds 1, 3 and 2 (each within the scatter of the next, the first and the last beyond it).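

At this saturated ring carbon, the aromatic ring can give way to a saturated one without a change beyond the scatter in this assay: cycloheptyl in place of 4-fluorophenyl gives a 1.4-fold higher number from compound 1 to compound 3 (0.14 log units; within the scatter), and cycloheptyl in place of 3,4-difluorophenyl gives a 1.6-fold lower number from compound 2 to compound 3 (0.20 log units; within the scatter). The earlier compounds shown here showed only the exchange of a hydrogen for a fluorine on the aromatic ring, whereas these steps replace the whole ring, and compound 3 cannot be ranked against compound 1 or compound 2. Nothing available explains why these groups give such similar readings.

The compounds shown leave open whether a smaller ring such as cyclopentyl or an open chain such as hexyl would read the same here. They also leave open how a cycloheptyl ring carrying an amine would behave.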